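Swapping a pyridinylmethyl amide for an oxolane amide

This account rests on a few compounds, and the source may have more. Where it says the series, first, only, none or still open, it means among the compounds named here.

Compound 1 `Cc1cc(C(=O)Nc2c(F)cccc2F)nn1Cc1cc(Cl)ccc1OCc1ccccc1` gives 3.7 in a physicochemical assay for lipophilicity, at pH 7.4; on this read-out higher numbers stand for higher lipophilicity and lower numbers for lower lipophilicity.
Compound 2 `Cc1cc(C(=O)NCc2ccccn2)nn1Cc1cc(Cl)ccc1OCc1ccccc1` gives > 3.7 in this assay, which is a limit of the assay and not a number.

Compound 2 therefore stands only at a limit, and its exact position is open. Going by the values given here, the single measured step, a number no lower from compound 1 to compound 2 (the limit leaves the size open), has no readable size because the limit of > 3.7 in this assay, at which 1 of the 2 values shown sits, caps it. Compound 3 `Cc1cc(NC(=O)C2CCOC2)nn1Cc1cc(Cl)ccc1OCc1ccccc1` differs from compound 2 in another way: ((oxolan-3-yl)carbonyl)amino in place of ((pyridin-2-yl)methyl)carbamoyl on an aromatic carbon. Among the compounds with values here, no measured step covers this change, so the expectation rests on the structures and on the one limit alone. Compound 3 is estimated at 3.2, between 2.6 and 3.8. The step expected is a number at least 0.50 log units lower from compound 2 to compound 3 (beyond the scatter).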

Compound 3, distribution coefficient: > 3.7
Compound 3 ended at the assay's limit; the forecaster's own chance of this, stated with the estimate: 15%; middle value at least 0.50 log units from the limit.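

Compound 3 gives > 3.7 in this assay, which is a limit of the assay and not a number. So with ((oxolan-3-yl)carbonyl)amino on this aromatic carbon, the read-out stays at the limit, just as it does with the ((pyridin-2-yl)methyl)carbamoyl group of compound 2. Neither step into compound 3, from compound 1 or from compound 2, can be read, because both run into this limit: the limit of > 3.7 in this assay, at which 2 of the 3 values shown sit.

From the compounds shown here alone, how far compound 2 and compound 3 lie apart remains open. What can be stated is a number no lower from compound 1 to compound 3 (the limit leaves the size open) and no more.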